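Side-chain swap on the shared core: compound 3 to compound 4

The source may report more compounds than this note shows. Statements on the series, on what has been measured and on what is new or still open speak of the compounds shown alone.

In a functional assay on HCT-116 cells (Homo sapiens) for inhibition (on this read-out higher numbers stand for weaker inhibition and lower numbers for stronger inhibition), compound 1 (`CCNC(=O)c1noc(-c2cc(C(C)C)c(O)cc2O)c1-c1cc(COCC(N)=O)no1`) gives 97 nM, compound 2 (`CCNC(=O)c1noc(-c2cc(C(C)C)c(O)cc2O)c1-c1cc(CNC(C)=O)no1`) gives 167 nM and compound 3 (`CCNC(=O)c1noc(-c2cc(C(C)C)c(O)cc2O)c1-c1cc(CN(C)C)no1`) gives 92 nM, so compound 3 stands within the scatter of both others. Compound 4 (`CCNC(=O)c1noc(-c2cc(C(C)C)c(O)cc2O)c1-c1cc(CN2CCN(C)CC2)no1`) carries 4-methylpiperazin-1-yl in place of dimethylamino on a saturated chain carbon bound to an aromatic carbon. Three measured steps changed this same place: a 1.1-fold lower number from compound 1 to compound 3 (0.02 log units; within the scatter), a 1.8-fold lower number from compound 2 to compound 3 (0.26 log units; within the scatter) and a 1.7-fold higher number from compound 1 to compound 2 (0.24 log units; within the scatter). All three stay within the scatter, so no step beyond the scatter is expected here. The expected step is a 1.1-fold higher number from compound 3 to compound 4 (0.04 log units; within the scatter). Compound 4 is estimated at 100 nM, with an expected range of 45 nM to 220 nM.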

Compound 4, half-maximal inhibitory concentration: 340 nM
Estimate against measurement, compound 4: 3.4-fold (0.53 log units) below; measured number outside the range, above it.
By their numbers in this assay, from the lowest: compounds 3, 1 and 2 (each within the scatter of the next); then compound 4.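

The place on a saturated chain carbon bound to an aromatic carbon is not indifferent to its substituent: carbamoylmethoxy, acetamido and dimethylamino stayed within the scatter of one another, but 4-methylpiperazin-1-yl gives a 3.7-fold higher number from compound 3 to compound 4 (0.57 log units; beyond the scatter) and also a 3.5-fold higher number from compound 1 to compound 4 (0.54 log units; beyond the scatter) and a 2.0-fold higher number from compound 2 to compound 4 (0.31 log units; beyond the scatter), all beyond the scatter. Compound 4 therefore stands apart from all three others. No evidence on the origin of this shift is at hand.

On these data alone, whether the higher number goes with the six-membered ring or with its second nitrogen stays open. Morpholine, piperidine or unmethylated piperazine at this place would separate these.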